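A Second Chloro on the Amide Aryl Ring

A few compounds are considered here, and "the series" means these few. Any claim that something is new, unique, unknown or untested is made for them only; others in the source may bear on it.

compound 1, `C=CC(=O)Nc1cccc(NC(=O)CSc2nc(Nc3ccccc3)c3ccccc3n2)c1`: 8740 nM
compound 2, `O=C(CSc1nc(Nc2ccccc2)c2ccccc2n1)Nc1ccc(F)cc1`: 9560 nM
compound 3, `O=C(CSc1nc(Nc2ccccc2)c2ccccc2n1)Nc1ccc(Cl)cc1`: 12900 nM

In a functional assay on PC-3 cells (Homo sapiens) for inhibition, read by MTT assay, with a stated time of 72 h (on this read-out lower numbers stand for stronger inhibition and higher numbers for weaker inhibition), compound 3 has the highest of the three numbers, yet its nearest neighbour is compound 2, with a 1.3-fold higher number from compound 2 to compound 3 (0.13 log units; within the scatter), and its furthest is compound 1, with a 1.5-fold higher number from compound 1 to compound 3 (0.17 log units; within the scatter), so the three stand together within the scatter. Compound 4, `O=C(CSc1nc(Nc2ccccc2)c2ccccc2n1)Nc1ccc(Cl)cc1Cl`, differs from compound 3 by chloro in place of hydrogen on an aromatic carbon. Among the compounds with values here, the step bearing on it is the halogen exchange on the same ring, a 1.3-fold higher number from compound 2 to compound 3 (0.13 log units; within the scatter), which stayed within the scatter; no measured step adds a second chloro. Compound 4 is therefore expected to show a 1.0-fold higher number from compound 3 to compound 4 (0.00 log units; within the scatter), no change beyond the scatter, and its number in this assay is estimated at 13000 nM, between 5000 nM and 35000 nM.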

Compound 4, half-maximal inhibitory concentration: 9110 nM
For compound 4 the middle estimate is 1.4-fold (0.15 log units) above the measured one; the measured number falls inside the stated range.
By their numbers in this assay, from the lowest: compounds 1, 4, 2 and 3 (each within the scatter of the next).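

In this assay, within the data shown here, chloro in place of hydrogen, ortho to a large group, gives a 1.4-fold lower number from compound 3 to compound 4 (0.15 log units; within the scatter) and so brings no change beyond the scatter, the first reading of a second substituent on this ring. The 2,4-dichlorophenyl group also stands within the scatter of the other amide substituents, with a 1.0-fold lower number from compound 2 to compound 4 (0.02 log units; within the scatter) and a 1.0-fold higher number from compound 1 to compound 4 (0.02 log units; within the scatter) on record, so the four groups shown are not told apart on this read-out. Nothing measured here speaks to why this is so.

From the compounds shown here alone, whether an amine or a carboxylic acid on this ring would move the number beyond the scatter stays open.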